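The source may report more compounds than this note shows. Statements on the series, on what has been measured and on what is new or still open speak of the compounds shown alone.

Of the compounds shown here, three of a shared core have been measured so far. Compound 1 `COc1ccc(-c2nc(C)c(C(=O)CSc3nc(-c4cccc(OC)c4)c(C#N)c(=O)[nH]3)s2)cc1` gives 71.3% in a functional assay on U-87MG ATCC cells for antiproliferative activity against U-87 MG (Homo sapiens), read by MTT assay, with a stated time of 48 h, tested at 5 uM; on this read-out higher numbers stand for a weaker effect at the one concentration tested and lower numbers for a stronger effect. Compound 2 `Cc1nc(-c2ccc(Cl)cc2)sc1C(=O)CSc1nc(-c2cccc(Cl)c2)c(C#N)c(=O)[nH]1` gives 80.2% in the same assay, and compound 3 `Cc1nc(-c2ccccc2)sc1C(=O)CSc1nc(-c2cccc(Cl)c2)c(C#N)c(=O)[nH]1` gives 86.9%. On these three numbers compound 2 stands second highest; its nearest neighbour is compound 3, whose value lies a number 6.7 percentage points higher from compound 2 to compound 3 (within the scatter), and compound 1 lies a little lower, both within the scatter, so no order among the three can be read from them.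

The step now followed leads from compound 2 to compound 4 `COc1cccc(-c2nc(SCC(=O)c3sc(-c4ccc(Cl)cc4)nc3C)[nH]c(=O)c2C#N)c1`. The change is methoxy in place of chloro on an aromatic carbon, sitting on the six-membered aromatic ring of carbon only, meta to a large group; read one bond further out it is 3-chlorophenyl to 3-methoxyphenyl. For the measured compounds named here, no measured pair shows this particular exchange. Going by the values given here, the only step that has been measured, from compound 2 to compound 3, exchanges a chloro for hydrogen on a different ring and stays within the scatter. Compound 1, which carries a methoxy on the same ring as compound 4 but differs from compound 2 in two places, gives a value within the scatter of compound 2. The author therefore expects no step beyond the scatter in this assay, a number 3.2 percentage points lower from compound 2 to compound 4 (within the scatter). The estimate for compound 4 is 77%, between 63% and 90%.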

Compound 4, a percentage reported as activity, at one concentration (the size of the read-out at that concentration, not a potency): 96.6%
Estimate against measurement, compound 4: 19.6 percentage points below; the measured number lies above the stated range.
By their numbers in this assay, from the lowest: compounds 1, 2, 3 and 4 (each within the scatter of the next, the first and the last beyond it).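

In this assay, the change from 3-chlorophenyl to 3-methoxyphenyl on the six-membered aromatic ring of carbon only, meta to a large group, is a real step, a number 16.4 percentage points higher from compound 2 to compound 4 (beyond the scatter), so at the one concentration tested this methoxy goes with a weaker effect than the chloro it replaces when the rest of the molecule is kept. For the compounds shown here, compound 4 also gives a second comparison that differs in one place, a number 25.3 percentage points higher from compound 1 to compound 4 (beyond the scatter), where chloro replaces methoxy on an aromatic carbon of the other aryl ring while the 3-methoxyphenyl stays, which shows that this second place can also shift the read-out beyond the scatter, whereas the only earlier step stayed within it. No measurement shown here accounts for either step.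

The compounds shown leave open whether methoxy in place of chloro at the first place would give a similar step with a methoxy rather than a chloro on the other aryl ring. They also leave open how an amine, a hydroxyl or a carboxylic acid on that same aromatic carbon would read in this assay.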